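Swapping the sulfonyl aryl group: a chlorophenyl analogue

The source may hold more compounds than are shown below. What is called first, only, known or untested is meant among the compounds shown, and "the series" means these compounds.

Three compounds share one core and differ only in the aryl group on the sulfonyl sulfur. Compound 1 `COc1ccc(-c2cc(=O)c3c(OC)cc(OC)cc3n2S(=O)(=O)c2ccc([N+](=O)[O-])cc2)cc1` carries a 4-nitrophenyl there, and in a functional assay on SUP-B15 cells (Homo sapiens) for antiproliferative activity, with a stated time of 72 h (on this read-out higher numbers stand for an effect only at larger amounts of compound and lower numbers for an effect already at smaller amounts), compound 1 gives 17100 nM. Compound 2 `COc1ccc(-c2cc(=O)c3c(OC)cc(OC)cc3n2S(=O)(=O)c2ccc(F)cc2)cc1` carries a 4-fluorophenyl. In this assay compound 2 reaches only the limit > 65500 nM, which is not a number. Compound 3 `COc1ccc(-c2cc(=O)c3c(OC)cc(OC)cc3n2S(=O)(=O)c2cc(F)c(F)c(F)c2)cc1` carries a 3,4,5-trifluorophenyl. In this assay compound 3 likewise sits at the limit > 65500 nM. Compound 3 thus stands at the edge of what this assay can report, as the limit of > 65500 nM in this assay, at which 2 of the 3 values shown sit, records. The measured steps show an at least 3.8-fold higher number from compound 1 to compound 2 (0.58 log units; beyond the scatter) and an at least 3.8-fold higher number from compound 1 to compound 3 (0.58 log units; beyond the scatter), while a step that the two limits leave unreadable from compound 2 to compound 3.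

Compound 4 `COc1ccc(-c2cc(=O)c3c(OC)cc(OC)cc3n2S(=O)(=O)c2ccc(Cl)cc2)cc1` differs from compound 3 by 4-chlorophenyl in place of 3,4,5-trifluorophenyl on a sulfonyl sulfur. The step of an at least 3.8-fold higher number from compound 1 to compound 2 (0.58 log units; beyond the scatter) shows that a single halogen on this ring already drives the number to the limit, so compound 4 is expected to stay weak, with an estimated step of an at least 1.3-fold lower number from compound 3 to compound 4 (0.11 log units; that floor lies within the scatter). The estimate for compound 4 in this assay is 50000 nM, expected between 15000 nM and 150000 nM.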

Compound 4, half-maximal effective concentration: > 34400 nM
Compound 4 gave a limit, no number; the forecaster's own chance of this, stated with the estimate: 55%; the middle value lies beyond the limit too.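

Compound 4 gives only a limit, not a number, and this limit differs from the one shared by the fluorinated compounds: the limit of > 34400 nM in this assay, at which 1 of the 4 values shown sits. Chloro in place of nitro gives an at least 2.0-fold higher number from compound 1 to compound 4 (0.30 log units; that floor lies within the scatter), so unlike the swaps to the fluorinated rings, this change alone does not establish a loss of effect in this assay. Among the compounds shown here, the steps among compound 2, compound 3 and compound 4 cannot be read, so the three halogen-bearing rings cannot be ranked against one another, and the 4-nitrophenyl of compound 1 remains the only group here with a measured number.

The compounds shown leave open how the sulfonyl aryl ring would respond to a nitrile or a carboxylic acid in place of the nitro group. They also leave open what an amine on that ring would do.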